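The source may hold more compounds than are shown below. What is called first, only, known or untested is meant among the compounds shown, and "the series" means these compounds.

The measured compounds:
Compound 1, `Cc1ccc(NC(=O)CSc2nc3cccnc3[nH]2)cc1C`, gives 11% in an assay on isolated protein for inhibition of Ectonucleotide pyrophosphatase/phosphodiesterase family member 1 (Homo sapiens), tested at 10 uM; on this read-out higher numbers stand for more inhibition at the one concentration tested (going by the name of the read-out) and lower numbers for less inhibition.
Compound 2, `COc1cccc(NC(=O)CSc2nc3cccnc3[nH]2)c1`, gives 30% in this assay.

Compound 2 stands highest of the two numbers in this assay; the nearest is compound 1, whose number is lower by a gap beyond the usual scatter. Among the measured compounds shown here, no step between these two compounds is worked out here, so of that pair only the two values themselves can be said.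

Compound 3, `N#Cc1cccc(NC(=O)CSc2nc3cccnc3[nH]2)c1`, has not yet been measured in this assay. It differs from compound 2 in one place: cyano in place of methoxy on an aromatic carbon. Both groups are without a ring and each carries one acceptor and no donor, as counted, and the place on the ring is unchanged. For the measured compounds named here, with no measured step of this kind among the compounds at hand, the direction of the change cannot be read from the data, and the step of a number 5 percentage points lower from compound 2 to compound 3 (within the scatter) is expected to be close to none beyond the scatter, leaning slightly downward. Compound 3 is therefore estimated at 25% in this assay, within a range from 5% to 48%.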

Compound 3, a percentage reported as inhibition, at one concentration (the size of the read-out at that concentration, not a potency): 45%
For compound 3 the middle estimate is 20 percentage points below the measured one, within the range that was stated.
By their numbers in this assay, from the lowest: compound 1; then compound 2; then compound 3.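

Among the compounds shown here, at this place, an aromatic carbon meta to a large group, the earlier compounds offered no single-place change, and the first one shows that the choice of group registers in this assay: cyano in place of methoxy gives a number 15 percentage points higher from compound 2 to compound 3 (beyond the scatter), a modest step. The two groups have the same counts of heavy atoms, hydrogen-bond donors and hydrogen-bond acceptors, and neither carries a ring or a net charge, so these counts do not separate them, although the values do. Nothing measured here bears on what lies behind the step.

The compounds shown leave open whether this step is particular to this place, as methoxy and cyano are compared on only one aromatic carbon, and how another group there, such as an amine or a carboxylic acid, would read in this assay. They also leave open the potency of compound 3, as its 45% gives the size of the inhibition at a single concentration and rests on one comparison within the shared core.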